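Nitro for fluoro on the core of compound 1

The source may report more compounds than this note shows. Statements on the series, on what has been measured and on what is new or still open speak of the compounds shown alone.

Among the compounds with values here, compound 1 `O=C(Cc1cccnc1)c1cc2cc(F)ccc2[nH]1` is the only member of this set with a reported number: in an in vitro assay on P815B cells for inhibition of Indoleamine 2,3-dioxygenase 1 (Mus musculus), tested at 20 uM (on this read-out lower numbers stand for less inhibition and higher numbers for more inhibition at the one concentration tested (going by the name of the read-out)), compound 1 gives 24%. Within the data shown here, compound 2 `O=C(Cc1ccncc1)c1cc2ccccc2[nH]1` is recorded in this assay as "not active" (no number reported), and compound 3 `O=C(Cc1cccnc1)c1[nH]c2ccccc2c1Br` is recorded in this assay as "not active" (no number reported); neither entry carries a figure, so no step between any two measured compounds can be sized. Compound 1 therefore stands alone as the one point against which a new entry can be weighed.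

Compound 4 `O=C(Cc1cccnc1)c1cc2cc([N+](=O)[O-])ccc2[nH]1` keeps the core of compound 1 and differs from it in a single way, (nitro in place of fluoro on an aromatic carbon), on an aromatic carbon of the six-membered carbon ring of the fused system. Among the measured compounds shown here, with no comparable pair in hand, the expected step in this assay from compound 1 to compound 4 is small and without a clear direction, about a number 1 percentage points higher from compound 1 to compound 4 (within the scatter), which lies within the usual scatter. For compound 4 in this assay the estimate is 25%, with a range from 5% to 50%.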

Compound 4, a percentage reported as inhibition, at one concentration (the size of the read-out at that concentration, not a potency): "not active" (no number reported)
For compound 4 the study gives words and no number, and the estimate cannot be compared.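

In this assay, within the data shown here, compound 4 is recorded as "not active" without a number, so no step from compound 1, at 24%, can be read. Nothing shown bears on this result.
As far as these compounds go, whether nitro in place of fluoro changes inhibition on the shared core, and by how much, stays open.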